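Acetylation of the tertiary hydroxyl in a diene ester series

The compounds below may be only part of what the source reports. "The series", "measured", "known", "first", "only" and "open" are said of these compounds alone.

Values in a physicochemical assay for lipophilicity (on this read-out lower numbers stand for lower lipophilicity and higher numbers for higher lipophilicity), so far:
compound 1 `CC(/C=C/CC(C)CCCC(C)(C)O)=C\C(=O)OC(C)C` gives 5.06
compound 2 `CC(=O)OC(C)(C)CCCC(C)C/C=C/C(C)=C/C(=O)OC(C)C` gives 5.98
compound 3 `CCSC(=O)/C=C(C)/C=C/CC(C)CCCC(C)(C)O` gives 5.89

Compound 2 differs from compound 1 by acetyl in place of hydrogen on an oxygen on a saturated carbon, and the step is a number 0.92 log units higher from compound 1 to compound 2 (beyond the scatter). Compound 3 differs from compound 1 by ethylsulfanyl in place of isopropoxy on a carbonyl carbon, with a step of a number 0.83 log units higher from compound 1 to compound 3 (beyond the scatter). Compound 2 and compound 3 lie within the usual scatter of each other, so nothing separates them on this read-out.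

Compound 4 `CCSC(=O)/C=C(C)/C=C/CC(C)CCCC(C)(C)OC(C)=O` is not yet measured. It differs from compound 3 by acetyl in place of hydrogen on an oxygen on a saturated carbon. This is the same change as acetyl in place of hydrogen on an oxygen on a saturated carbon, made at the same place word for word; it occurs twice among these four compounds. The two cores differ by ethylsulfanyl in place of isopropoxy on a carbonyl carbon.

The expected step from compound 3 to compound 4 is a number 0.91 log units higher from compound 3 to compound 4 (beyond the scatter), set beside the measured a number 0.92 log units higher from compound 1 to compound 2 (beyond the scatter); it rests on that single earlier step of the same change. Compound 4 is therefore estimated at 6.8, with a range from 6.4 to 7.2.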

Compound 4, partition coefficient: 6.81
Compound 4: the middle estimate sits 0.01 log units below what was measured; measured number inside the range.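

In this assay, acetyl in place of hydrogen on an oxygen on a saturated carbon gives both a number 0.92 log units higher from compound 3 to compound 4 (beyond the scatter) and a number 0.92 log units higher from compound 1 to compound 2 (beyond the scatter) and so has the same size on the two cores. Ethylsulfanyl in place of isopropoxy on a carbonyl carbon likewise gives both a number 0.83 log units higher from compound 2 to compound 4 (beyond the scatter) and a number 0.83 log units higher from compound 1 to compound 3 (beyond the scatter) and so, within these four compounds, the two changes simply add. This covers a single pair of cores and shows nothing about carrying the change to any other core, and no measurement at hand bears on why the steps agree.

Open, as far as these compounds go, is whether the same step holds where a carboxylic acid or an amide stands on the carbonyl carbon in place of the isopropoxy or ethylsulfanyl group. Also open, from the compounds shown here alone, is how a longer acyl chain such as butyryl would compare with acetyl on the same oxygen in this assay.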